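A few compounds are considered here, and "the series" means these few. Any claim that something is new, unique, unknown or untested is made for them only; others in the source may bear on it.

Half-lives in an ADME assay (liver) for metabolic stability, with Liver microsome (Homo sapiens) as the target, read by LC-MS, using microsomes and NADPH, tested at 1 uM (a higher number here means that the compound lasts longer, a lower number that the compound disappears faster), for the three measured members of the series:

Compound 1 `CC(C)(C)c1cc(NC(=O)[C@@H]2CCCCN2Cc2ccc(Cl)cc2)no1`: 0.15 h
Compound 2 `CC(C)(C)c1cc(NC(=O)[C@@H]2CCCCN2CC2CC2)no1`: 0.15 h
Compound 3 `CC(C)CN1CCCC[C@H]1C(=O)Nc1cc(C(C)(C)C)on1`: 0.1 h

The three numbers sit close together. Compound 3 differs from compound 1 by a 1.5-fold lower number from compound 1 to compound 3 (0.18 log units; within the scatter) and from compound 2 by a 1.5-fold lower number from compound 2 to compound 3 (0.18 log units; within the scatter), neither beyond the scatter, so compound 3 cannot be set apart from the other two on these values; likewise no change at the digits printed from compound 1 to compound 2 (within the scatter) separates nothing.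

Compound 4 `CC(C)(C)c1cc(NC(=O)[C@@H]2CCCCN2C(=O)c2ccccc2)no1` is the next member: benzoyl in place of isobutyl on an amine nitrogen in a ring. The measured steps all exchange one substituent on the saturated chain carbon bound to the amine nitrogen in the ring and leave that nitrogen itself untouched; none of them puts a carbonyl on the nitrogen. Within the data shown here, they therefore bear on the present change only in showing that the series has so far stayed within a narrow band whatever sat on that chain carbon, and the data hold no step of the kind now made. The expected step in this assay, a 1.5-fold higher number from compound 3 to compound 4 (0.18 log units; within the scatter), is accordingly set at nothing beyond the scatter, with a wide range. Compound 4 is estimated at 0.15 h, between 0.05 h and 0.6 h.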

Compound 4, half-life: 0.683 h
Compound 4: middle estimate off by 4.6-fold (0.66 log units), on the low side, outside the stated range (above it).
By their numbers in this assay, from the lowest: compounds 3, 1 and 2 (each within the scatter of the next); then compound 4.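

At the amine nitrogen in the ring, this assay responds to benzoyl in place of isobutyl with a 6.8-fold higher number from compound 3 to compound 4 (0.83 log units; beyond the scatter) while benzoyl in place of cyclopropylmethyl gives a 4.6-fold higher number from compound 2 to compound 4 (0.66 log units; beyond the scatter) and benzoyl in place of 4-chlorobenzyl gives a 4.6-fold higher number from compound 1 to compound 4 (0.66 log units; beyond the scatter) in the same direction. Unlike the exchanges among the earlier compounds, which all stayed within the scatter, this change at the nitrogen moves the half-life beyond it, and all three comparisons agree, though they rest on compound 4 alone. No measurement at hand bears on the origin of this rise.

As far as these compounds go, whether the carbonyl alone is enough, without the aromatic ring of benzoyl, remains open. An acetyl group or a phenylsulfonyl group on that nitrogen would bear on this question.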